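This account rests on a few compounds, and the source may have more. Where it says the series, first, only, none or still open, it means among the compounds named here.

Compound 1 `O=C(COc1cccc2ccccc12)N/N=C/c1ccc(O)cc1` gave 3.73 in a physicochemical assay for lipophilicity, measured as octanol-water partition; a lower number here means a more polar compound, a higher number a more lipophilic compound.
Compound 2 `COc1ccc(/C=N/NC(=O)COc2cccc3ccccc23)cc1O` gave 3.48 in this assay.
Compound 3 `C/C(=N\NC(=O)COc1cccc2ccccc12)c1ccccc1Br` gave 4.44 in this assay.

Among these three numbers compound 1 stands second highest. Compound 2 is its nearest neighbour, and its number lies within the scatter of compound 1, so no order between the two can be read. Compound 3 is furthest from compound 1, with the higher number, and that gap lies beyond the scatter.

Compound 4 `CSc1ccc(/C=N/NC(=O)COc2cccc3ccccc23)cc1` has not yet been measured in this assay. It differs from compound 1 in one place: methylsulfanyl in place of hydroxy on an aromatic carbon. For the measured compounds named here, no pair of measured compounds shows this change, so its size has to be estimated. An upward step beyond the scatter is expected, a number 1.27 log units higher from compound 1 to compound 4 (beyond the scatter). Compound 4 is therefore estimated at 5, in a range from 4.6 to 5.4.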

Compound 4, partition coefficient: 4.11
The estimate for compound 4 lay 0.89 log units above the measured number; measured number below the stated range.
By their numbers in this assay, from the lowest: compounds 2 and 1 (each within the scatter of the next); then compound 4; then compound 3.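

For the compounds shown here, the change from 4-hydroxyphenyl to 4-(methylsulfanyl)phenyl gives a number 0.38 log units higher from compound 1 to compound 4 (beyond the scatter) in this assay and is the first step measured at this position. It shows that the position responds to this change, though the step is modest and rests on a single pair. Nothing measured here accounts for its size.

From the compounds shown here alone, whether an amine or a carboxylic acid in the same place would raise or lower the number remains open. So does whether a longer chain on the sulfur would extend the step.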